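The source may report more compounds than this note shows. Statements on the series, on what has been measured and on what is new or still open speak of the compounds shown alone.

Measured compounds:
compound 1 `Cc1ccc(-c2cs/c(=N/NC(=O)CSc3nnnn3-c3ccccc3)n2-c2ccccc2)cc1` — 38.8%
compound 2 `Cc1ccc(-c2cs/c(=N/NC(=O)CSc3ncccn3)n2-c2ccccc2)cc1` — 82.7%
compound 3 `Cn1nnnc1SCC(=O)N/N=c1/scc(-c2ccc(C#N)cc2)n1-c1ccccc1` — 43.9%

In a functional assay on C6 cells (Rattus norvegicus) for cytotoxicity, read by MTT assay, with a stated time of 24 h, tested at 25 ug/mL (on this read-out lower numbers stand for a stronger effect and higher numbers for a weaker effect at the one concentration tested), compound 3 gives 43.9%, the second highest of the three numbers. Its nearest neighbour is compound 1, whose value in this assay is 38.8%; the two lie within the scatter of each other, so no order can be read between them. The furthest is compound 2, which in this assay gives 82.7%, a value beyond the scatter from compound 3.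

Compound 4 `Cc1ccc(-c2cs/c(=N/NC(=O)CSc3nnnn3C)n2-c2ccccc2)cc1` has not yet been measured in this assay. It differs from compound 3 in one place (methyl in place of cyano on an aromatic carbon). Among the compounds with values here, the only measured step, a number 43.9 percentage points higher from compound 1 to compound 2 (beyond the scatter), concerns the group on the sulfur and not the group on the six-membered aromatic ring of carbon only, so it does not bear on this change. Compounds 1 and 3 differ in two places, among them the same cyano-for-methyl exchange, and their two values sit within the scatter of each other; that is the only hint available, and it is weak.

Compound 4 is therefore expected to show a step of a number 1.9 percentage points lower from compound 3 to compound 4 (within the scatter), none beyond the scatter. The estimate for compound 4 in this assay is 42%, with a range from 25% to 62%.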

Compound 4, a percentage reported as activity, at one concentration (the size of the read-out at that concentration, not a potency): 60.7%
Compound 4: middle estimate off by 18.7 percentage points, on the low side, within the range that was stated.
By their numbers in this assay, from the lowest: compounds 1 and 3 (each within the scatter of the next); then compound 4; then compound 2.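

In this assay, within the data shown here, the change from 4-cyanophenyl to 4-methylphenyl gives a number 16.8 percentage points higher from compound 3 to compound 4 (beyond the scatter), so the group on this six-membered aromatic ring does affect the read-out, with the methyl compound having the weaker effect at the one concentration tested; the earlier compounds never changed this group alone and could not show this. The group on the sulfur also proves more finely graded than the first step suggested: with the 4-methylphenyl group kept, 1-methyl-1H-tetrazol-5-yl in place of pyrimidin-2-yl gives a number 22 percentage points lower from compound 2 to compound 4 (beyond the scatter), while methyl in place of phenyl on the tetrazole nitrogen gives a number 21.9 percentage points higher from compound 1 to compound 4 (beyond the scatter), which places compound 4 in the middle of that series. No measurement available here explains the origin of these steps.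

As far as these compounds go, it remains open whether a methoxy group or a chlorine atom at this place would behave like cyano or like methyl, and whether the step between the two has the same size when the sulfur carries 1-phenyl-1H-tetrazol-5-yl or pyrimidin-2-yl. With one concentration only, these numbers also leave the potency of the compounds undefined.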